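Tertiary amine variation on the quinone core

The source may hold more compounds than are shown below. What is called first, only, known or untested is meant among the compounds shown, and "the series" means these compounds.

Compound 1 `O=C1C=C(NCc2ccccc2)C(=O)c2c1nc1n2[C@H]2OC[C@@H](O)[C@H]2OC1`: 2670 nM
Compound 2 `O=C1C=C(Nc2ccccc2)C(=O)c2c1nc1n2[C@H]2OC[C@@H](O)[C@H]2OC1`: 1730 nM
Compound 3 `CCCN(CCC)C1=CC(=O)c2nc3n(c2C1=O)[C@H]1OC[C@@H](O)[C@H]1OC3`: > 16000 nM

In a functional assay on MGC-803 cells (Homo sapiens) for inhibition, read by sulforhodamine B assay (a lower number here means a stronger inhibitor, a higher number a weaker inhibitor), compound 1 gives 2670 nM and compound 2 gives 1730 nM; the two lie a 1.5-fold lower number from compound 1 to compound 2 (0.19 log units; within the scatter). Compound 3 reports only a limit, > 16000 nM, so its standing rests on that boundary (the limit of > 16000 nM in this assay, at which 1 of the 3 values shown sits). Both measured steps toward it are beyond the scatter: an at least 5.9-fold higher number from compound 1 to compound 3 (0.77 log units; beyond the scatter) and an at least 9.2-fold higher number from compound 2 to compound 3 (0.96 log units; beyond the scatter). Compound 4 `O=C1C=C(N2CCC2)C(=O)c2c1nc1n2[C@H]2OC[C@@H](O)[C@H]2OC1` carries azetidin-1-yl in place of dipropylamino on a double-bonded ring carbon. Within the data shown here, no measured step tests a cyclic tertiary amine directly; the two steps into compound 3 show only that a tertiary amine sits far from the secondary ones. Compound 4 is therefore expected near compound 3, perhaps slightly stronger, at 12000 nM (range 3000 nM to 40000 nM), a step of an at least 1.3-fold lower number from compound 3 to compound 4 (0.12 log units; that floor lies within the scatter) expected.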

Compound 4, half-maximal inhibitory concentration: > 16000 nM
Compound 4 ended at the assay's limit; the forecaster's own chance of this, stated with the estimate: 45%; middle value at least 1.3-fold (0.12 log units) away from the limit.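

Azetidin-1-yl in place of the secondary amines on the double-bonded ring carbon gives an at least 9.2-fold higher number from compound 2 to compound 4 (0.96 log units; beyond the scatter) and an at least 5.9-fold higher number from compound 1 to compound 4 (0.77 log units; beyond the scatter), so a tertiary amine tied into a ring does not keep the level of the anilino and benzylamino compounds, any more than open dipropylamino does. In this assay compound 4 stands at a limit, not a number: the limit of > 16000 nM in this assay, at which 2 of the 4 values shown sit.

The step between compound 3 and compound 4 cannot be read, so these two tertiary amines stay unranked. Open, on these data alone, is whether a small secondary amine such as methylamino keeps the level of compound 1 and compound 2, and whether morpholine behaves like azetidin-1-yl.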